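Chloro for Fluoro in a Liver Stability Series

This account rests on a few compounds, and the source may have more. Where it says the series, first, only, none or still open, it means among the compounds named here.

Of the compounds shown here, three have been measured in an ADME assay on S9 fraction from liver (Rattus norvegicus) for metabolic stability, read by LC-MS, using NADPH, with a stated time of 30 min; on this read-out lower numbers stand for a less stable compound and higher numbers for a more stable compound. Compound 1 has the structure `COC(=O)c1ccc(-c2nnn(CC(=O)C(C)Oc3ccc(Oc4ccc(F)cc4)cc3)n2)cc1`. In this assay compound 1 reaches only a limit of the assay, recorded as < 5%, not a number. Compound 2, with the structure `COC(=O)c1ccc(-c2nnn(CC(=O)C(C)Oc3ccc(Oc4ccc(Cl)cc4)cc3)n2)cc1`, differs from compound 1 by chloro in place of fluoro on an aromatic carbon. In this assay compound 2 also reaches only a limit, recorded as < 5%. The step that the two limits leave unreadable from compound 1 to compound 2 therefore cannot be read, because both values sit at the limit of < 5% in this assay, at which 2 of the 3 values shown sit.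

Compound 3 has the structure `CC(Oc1ccc(Oc2ccc(F)cc2)cc1)C(=O)Cn1nnc(-c2ccc(C(=O)O)cc2)n1` and differs from compound 1 by hydrogen in place of methyl on an oxygen next to a carbonyl group, which is the only difference between the two cores. In this assay, among the compounds with values here, compound 3 gives 33%, the only real number among the three. Within the data shown here, the step of a number at least 28 percentage points higher from compound 1 to compound 3 (beyond the scatter) is the one readable change in the set.

Compound 4 is not yet measured; its structure is `CC(Oc1ccc(Oc2ccc(Cl)cc2)cc1)C(=O)Cn1nnc(-c2ccc(C(=O)O)cc2)n1`. It differs from compound 3 by chloro in place of fluoro on an aromatic carbon, the same change that leads from compound 1 to compound 2, made on the core of compound 3. That earlier change left no readable step, so there is nothing to say how large the move from compound 3 to compound 4 should be. The estimate rests on compound 3 alone, because compound 3 gives 33% in this assay. For compound 4 the expected step is a number 3 percentage points lower from compound 3 to compound 4 (within the scatter), close to no change. Compound 4 is therefore expected to give about 30%, estimated within 12% to 50%.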

Compound 4, percent of the compound remaining: 32%
The estimate for compound 4 lay 2 percentage points below the measured number; the measured number falls inside the stated range.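

Hydrogen in place of methyl on an oxygen next to a carbonyl group, which turns a methyl ester into a carboxylic acid, now stands on two cores, one bearing fluoro and one bearing chloro, and in this assay the new step is a number at least 27 percentage points higher from compound 2 to compound 4 (beyond the scatter), which points the same way as the earlier a number at least 28 percentage points higher from compound 1 to compound 3 (beyond the scatter). So this change carries from one core to the other in direction, but the two methyl esters give no real number, and how far the two steps match in size stays unknown: the same change on two cores in this assay, a number at least 28 percentage points higher (beyond the scatter) from compound 1 to compound 3 and a number at least 27 percentage points higher (beyond the scatter) from compound 2 to compound 4; the limit leaves it open whether they differ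

Chloro in place of fluoro gives a number 1 percentage points lower from compound 3 to compound 4 (within the scatter), yet the same swap on the core of compound 1 cannot be read, so these compounds show nothing about whether that swap behaves alike on both cores: the limit of < 5% in this assay, at which 2 of the 4 values shown sit.

Still open, as far as these compounds go, is how this assay would respond to bromo, a nitrile or a methoxy group standing where fluoro and chloro stand. Also open, from the compounds shown here alone, is whether an ethyl ester or an amide would follow the methyl ester or the carboxylic acid on this core.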